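A 4-(tert-butyl)phenyl group replaces 1-methyl-1H-indol-6-yl

The source may report more compounds than this note shows. Statements on the series, on what has been measured and on what is new or still open speak of the compounds shown alone.

Among the measured compounds shown here, in a functional assay on HCT-116 cells (Homo sapiens) for inhibition, read by CCK-8 assay, with a stated time of 48 h (on this read-out lower numbers stand for stronger inhibition and higher numbers for weaker inhibition), compound 1 `COc1cc(-c2ccnc3cc(-c4ccc(C)cc4)nn23)cc(OC)c1OC` gives 48 nM and compound 2 `COc1cc(-c2ccnc3cc(-c4ccc5ccn(C)c5c4)nn23)cc(OC)c1OC` gives 1040 nM, the higher of only two numbers so far. For the measured compounds named here, the single measured step, a 22-fold higher number from compound 1 to compound 2 (1.34 log units; beyond the scatter), is large and lies beyond the scatter. It came from putting 1-methyl-1H-indol-6-yl in place of 4-methylphenyl. Compound 3 `COc1cc(-c2ccnc3cc(-c4ccc(C(C)(C)C)cc4)nn23)cc(OC)c1OC` changes the same place on the shared core: 4-(tert-butyl)phenyl in place of 1-methyl-1H-indol-6-yl on an aromatic carbon. The incoming group resembles the 4-methylphenyl of compound 1 at 48 nM, with tert-butyl instead of methyl, so much of that large step should be reversed. Going by the values given here, no measured compound shows what the larger tert-butyl does here, so some of the gain may be lost. The expected change is a 6.9-fold lower number from compound 2 to compound 3 (0.84 log units; beyond the scatter), a clear move toward stronger inhibition. The estimated value for compound 3 is 150 nM, with an expected range of 40 nM to 600 nM.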

Compound 3, half-maximal inhibitory concentration: > 10000 nM
Compound 3: a limit, no number; the forecaster's own chance of this, stated with the estimate: 3%; middle value at least 66-fold (1.82 log units) away from the limit.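

In this assay compound 3 gives > 10000 nM as a limit of the assay, not a number: the limit of > 10000 nM in this assay, at which 1 of the 3 values shown sits.

Changing only methyl to tert-butyl on the phenyl ring brings an at least 200-fold higher number from compound 1 to compound 3 (2.31 log units; beyond the scatter) and so shows that at this place the group carried on the ring matters, not only the presence of a phenyl ring. Compound 2 was already weaker than compound 1, yet replacing its 1-methyl-1H-indol-6-yl brings an at least 9.6-fold higher number from compound 2 to compound 3 (0.98 log units; beyond the scatter) and shows that returning to a phenyl ring does not by itself restore strength.

The compounds shown leave open whether ethyl or isopropyl in place of that methyl would keep the number of compound 1 or lose it. They also leave open how a methoxy group or an amine would read there.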